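A few compounds are considered here, and "the series" means these few. Any claim that something is new, unique, unknown or untested is made for them only; others in the source may bear on it.

Measured so far:
compound 1 `CC(C)CCCN(C)Cc1ccc(C2=CCCN(C)C2)cc1`: > 50000 nM
compound 2 `COc1ccc(CN(C)Cc2ccc(C3=CCCN(C)C3)cc2)cc1`: > 50000 nM

In an ADME assay on HL-60 cells (Homo sapiens) for cytotoxicity, read by MTT assay, with a stated time of 24 h (a higher number here means a weaker inhibitor, a lower number a stronger inhibitor), compound 1 gives only a limit, > 50000 nM. In this assay compound 2 likewise gives only a limit, > 50000 nM. Both values sit at the limit of > 50000 nM in this assay, at which 2 of the 2 values shown sit, so neither is a measured number, and the step that the two limits leave unreadable from compound 1 to compound 2 cannot be sized. Compound 3 `CN1CCC=C(c2ccc(CN(C)CCCc3ccccc3)cc2)C1` is not yet measured; it differs from compound 2 by phenethyl in place of 4-methoxyphenyl on a saturated chain carbon bound to an amine nitrogen. Among the measured compounds shown here, the one step on record bears on the same place in the molecule but tells nothing of size or direction, since both of its ends are limits. There is therefore no basis for expecting compound 3 to move past the limit, and the expected step of a number no higher from compound 2 to compound 3 (the limit leaves the size open) is no more than a guess of no change. Compound 3 is estimated at 50000 nM, within 15000 nM to 200000 nM, most likely reported again as a limit.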

Compound 3, half-maximal inhibitory concentration: > 50000 nM
Compound 3: no number, only a limit (the forecaster's own chance of this, stated with the estimate: 80%); the middle value lies on the limit itself.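

No step among compound 1, compound 2 and compound 3 can be read, since each gives only a limit: the limit of > 50000 nM in this assay, at which 3 of the 3 values shown sit.

The compounds shown leave open whether swapping these groups changes the result in this assay at all, and if so, in which direction and by how much.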